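Adding a Pyridinyl Ring to Compound 1

This account rests on a few compounds, and the source may have more. Where it says the series, first, only, none or still open, it means among the compounds named here.

Compound 1, `Cc1cccc(NC(=O)c2cccc(C#N)c2)n1`: 330 nM
Compound 2, `N#Cc1cc(C#Cc2ccccn2)ccc1-c1ccc(F)cc1`: 3 nM
Compound 3, `Cc1cccc(NC(=O)c2ccc(-c3ccccc3)nc2)n1`: 356 nM

These three compounds were tested in an in vitro assay on HEK-293T cells for displacement of a labelled ligand from metabotropic glutamate receptor 5 (Rattus norvegicus), read by scintillation counting; a lower number here means a stronger inhibitor, a higher number a weaker inhibitor. Compound 1 stands second highest of the three numbers. Its nearest neighbour is compound 3, whose number lies within the usual scatter of compound 1, so the two cannot be told apart. Compound 2 lies far lower, well beyond the scatter, and it is the only one of the three that carries an aromatic ring directly attached to the ring bearing the nitrile.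

Compound 4, `Cc1cccc(NC(=O)c2ccc(-c3cccnc3)c(C#N)c2)n1`, has not yet been measured in this assay. It differs from compound 1 in one place: pyridin-3-yl in place of hydrogen on an aromatic carbon. Within the data shown here, no measured pair shows this exact change, so the size of the step is open. Because compound 2 gives 3 nM with a related arrangement of nitrile and aryl ring, a step toward a lower number is expected from compound 1 to compound 4, estimated at an 8.3-fold lower number from compound 1 to compound 4 (0.92 log units; beyond the scatter). Compound 4 is therefore expected to give about 40 nM, within a range of 8 nM to 200 nM.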

Compound 4, inhibition constant: 2040 nM
The estimate for compound 4 lay 51-fold (1.71 log units) below the measured number; the whole stated range lies below it.
By their numbers in this assay, from the lowest: compound 2; then compounds 1 and 3 (each within the scatter of the next); then compound 4.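

In this assay, placing pyridin-3-yl on this aromatic carbon, ortho to a cyano group and para to a large group, gives a 6.2-fold higher number from compound 1 to compound 4 (0.79 log units; beyond the scatter). Among these compounds, this is the first reading at this position of the shared core, and it shows that adding this ring here makes the inhibitor weaker rather than stronger, a modest but real step. Nothing measured here accounts for the loss.

Going by these compounds, how a methoxy group, a chlorine atom or an amine on this same carbon would compare with pyridin-3-yl remains open, so a single ring cannot show whether the position tolerates only small groups or merely disfavours this one. Also open, on these data alone, is whether the same addition would give a step of this size on a core lacking the nitrile.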